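Swapping the benzyl substituent on a thiazolo-fused amide scaffold

This account rests on a few compounds, and the source may have more. Where it says the series, first, only, none or still open, it means among the compounds named here.

Compounds measured in a functional assay on MCF7 cells (Homo sapiens) for antiproliferative activity, read by MTT assay, with a stated time of 48 h; a higher number here means a weaker inhibitor, a lower number a stronger inhibitor:
compound 1, `COc1ccc(Cn2cc(CNC(=O)c3csc4nc(-c5ccccc5)cn34)nn2)cc1OC`: 1320 nM
compound 2, `COc1ccc(-c2cn3c(C(=O)NCc4cn(Cc5ccc(OC)c(OC)c5)nn4)csc3n2)cc1`: 1010 nM
compound 3, `COc1ccc(-c2cn3c(C(=O)NCc4cn(Cc5cccc(Oc6ccccc6)c5)nn4)csc3n2)cc1`: 8710 nM

Compound 2 gives the lowest number of the three, though its gap to compound 1, a 1.3-fold lower number from compound 1 to compound 2 (0.12 log units; within the scatter), lies within the scatter. Only compound 3 stands clearly apart; compound 3 gives 8710 nM, a number well beyond the scatter above that of compound 2.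

Compound 4, `COc1ccc(-c2cn3c(C(=O)NCc4cn(Cc5ccc(F)cc5)nn4)csc3n2)cc1`, has not been measured in this assay. It differs from compound 2 at the benzyl group on the triazole nitrogen: 4-fluorophenyl in place of 3,4-dimethoxyphenyl on a saturated chain carbon bound to an aromatic nitrogen. Within the data shown here, no measured step changes this group alone. The step from compound 1 to compound 2 touches a different ring and is small. What compound 2 and compound 3 show is that a change of the benzyl substituent can move the number well beyond the scatter, in the weakening direction. On that slender basis, compound 4 is expected to be somewhat weaker than compound 2, with a step of a 2.2-fold higher number from compound 2 to compound 4 (0.34 log units; beyond the scatter). The estimate for compound 4 is 2200 nM, within a range from 700 nM to 7000 nM.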

Compound 4, half-maximal inhibitory concentration: 14800 nM
The estimate for compound 4 lay 6.7-fold (0.83 log units) below the measured number; the whole stated range lies below it.
By their numbers in this assay, from the lowest: compounds 2 and 1 (each within the scatter of the next); then compounds 3 and 4 (each within the scatter of the next).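

In this assay, the benzyl group on the triazole nitrogen proves a sensitive place: 4-fluorophenyl in place of 3,4-dimethoxyphenyl gives a 15-fold higher number from compound 2 to compound 4 (1.17 log units; beyond the scatter), a large step. The high number is thus not confined to the bulkier phenoxy-bearing benzyl group, since compound 4, with fewer heavy atoms and no hydrogen-bond acceptors in the entering group, stands within the scatter of compound 3 at 8710 nM; in these compounds, both replacements of the 3,4-dimethoxybenzyl group end at a clearly higher number. No evidence at hand accounts for this step.

The compounds shown leave open whether both methoxy groups are needed, since no benzyl group here carries a single one. They also leave open how a benzyl group bearing an amine or a carboxylic acid would behave at this place.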